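The source may hold more compounds than are shown below. What is called first, only, known or untested is meant among the compounds shown, and "the series" means these compounds.

Measured so far in an ADME assay for protein binding, using equilibrium dialysis, at pH 7.4, tested at 2 uM; on this read-out lower numbers stand for a smaller free fraction and higher numbers for a larger free fraction:
- compound 1 `CC(C)N(C(=O)C1CCCCC1)c1cc(C#CC(C)(C)C)sc1C(=O)O` gives 0.18
- compound 2 `CC(C)N(C(=O)[C@H]1CC[C@@H]2C[C@@H]2CC1)c1cc(C#CC(C)(C)C)sc1C(=O)O` gives 0.08

Compound 2 at 0.08 holds the lower of the two numbers, and its gap to compound 1 lies beyond the scatter. Still unmeasured is compound 3 `CC(C)N(C(=O)[C@@H]1CC[C@@H]2C[C@@H]2CC1)c1cc(C#CC(C)(C)C)sc1C(=O)O` which relates to compound 2 as follows: the two compounds have the same atoms and bonds and differ only in configuration as drawn: 1 of 3 stereo elements differ; a stereocentre at a saturated ring carbon is drawn r in compound 2 and s in compound 3 and nothing else separates them.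

Among the compounds with values here, the only measured step, a 2.3-fold lower number from compound 1 to compound 2 (0.35 log units; beyond the scatter) is modest and exchanges the ring group on the carbonyl carbon. Within the data shown here, it does not test configuration, and no measured pair differs in configuration alone. No step beyond the scatter is therefore expected in this assay in either direction, so the anchor is compound 2 at 0.08 as measured. The expected change is no change at the digits printed from compound 2 to compound 3 (within the scatter) as an estimate within the scatter. Compound 3 is estimated at 0.08 within an expected range of 0.04 to 0.16 for now.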

Compound 3, unbound fraction: 0.05
For compound 3 the middle estimate is 1.6-fold (0.20 log units) above the measured one; measured number inside the range.
By their numbers in this assay, from the lowest: compounds 3 and 2 (each within the scatter of the next); then compound 1.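

In this assay, within the data shown here, the first comparison of configuration alone gives a 1.6-fold lower number from compound 2 to compound 3 (0.20 log units; within the scatter), so the r and s forms at this saturated ring carbon are not separated on this read-out. The comparison isolates that one stereocentre: the fact that compounds 2 and 3 differ only in the configuration as drawn. The exchange on the carbonyl carbon now has a second reading, a 3.6-fold lower number from compound 1 to compound 3 (0.56 log units; beyond the scatter), so with either drawn configuration at this centre, the group with the three-membered and seven-membered rings stands beyond the scatter from the six-membered ring of compound 1.

The compounds shown leave open how a plain cycloheptyl group on the carbonyl carbon, without the three-membered ring, would read in this assay. Also open, going by these compounds, is whether changing either of the other two stereo elements would give a step beyond the scatter.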